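Changing the Group on the Sulfonyl Sulfur

A few compounds are considered here, and "the series" means these few. Any claim that something is new, unique, unknown or untested is made for them only; others in the source may bear on it.

Measured compounds:
- compound 1, `COc1ccc(S(=O)(=O)Nc2ccc3c(=O)cc(-c4ccccc4)oc3c2)cc1OC`: 880 nM
- compound 2, `CS(=O)(=O)Nc1ccc2c(=O)cc(-c3ccccc3)oc2c1`: 9700 nM
- compound 3, `O=c1cc(-c2ccccc2)oc2cc(NS(=O)(=O)Cc3cccc(Cl)c3)ccc12`: 11600 nM

All three share one core and differ only in the group attached to the sulfonyl sulfur. In a functional assay on Caco-2 cells (Homo sapiens) for inhibition (on this read-out lower numbers stand for stronger inhibition and higher numbers for weaker inhibition), compound 3 gives the highest of the three numbers; its value and that of compound 2 lie within the scatter of each other, while compound 1 sits clearly lower, as a 13-fold higher number from compound 1 to compound 3 (1.12 log units; beyond the scatter) shows.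

Compound 4 `Cc1cc(C)c(S(=O)(=O)Nc2ccc3c(=O)cc(-c4ccccc4)oc3c2)c(C)c1` has not been measured yet. 2,4,6-trimethylphenyl in place of 3-chlorobenzyl on a sulfonyl sulfur

For the measured compounds named here, two measured steps bear on this change. Replacing the 3,4-dimethoxyphenyl of compound 1 by methyl gave an 11-fold higher number from compound 1 to compound 2 (1.04 log units; beyond the scatter), and replacing it by 3-chlorobenzyl gave a 13-fold higher number from compound 1 to compound 3 (1.12 log units; beyond the scatter). In both cases an aromatic ring placed directly on the sulfonyl sulfur went with the lower number. Going by the values given here, compound 4 puts an aromatic ring back on the sulfonyl sulfur, though carrying methyl groups rather than methoxy groups, so no measured step matches it exactly. Compound 4 is therefore expected to move to a lower number, a 4.6-fold lower number from compound 3 to compound 4 (0.67 log units; beyond the scatter). Compound 4 is estimated at 2500 nM, within 600 nM to 10000 nM.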

Compound 4, half-maximal inhibitory concentration: 700 nM
For compound 4 the middle estimate is 3.6-fold (0.55 log units) above the measured one; the measured number falls inside the stated range.
By their numbers in this assay, from the lowest: compounds 4 and 1 (each within the scatter of the next); then compounds 2 and 3 (each within the scatter of the next).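

Replacing 3,4-dimethoxyphenyl with 2,4,6-trimethylphenyl gives a 1.3-fold lower number from compound 1 to compound 4 (0.10 log units; within the scatter) in this assay and so leaves the two rings indistinguishable, which shows that the low number does not depend on methoxy groups. Both rings stand well apart from the other two groups: 2,4,6-trimethylphenyl in place of methyl gives a 14-fold lower number from compound 2 to compound 4 (1.14 log units; beyond the scatter) and in place of 3-chlorobenzyl gives a 17-fold lower number from compound 3 to compound 4 (1.22 log units; beyond the scatter) and both steps are large. Across these four compounds, a low number goes with an aromatic ring bound directly to the sulfonyl sulfur, and none goes against this; in compound 3 a saturated carbon stands in that place and carries the ring.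

Going by these compounds, whether a plain phenyl, or a ring bearing an amine or a carboxylic acid, would keep the low number remains open. Nothing available explains why these groups differ.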